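A few compounds are considered here, and "the series" means these few. Any claim that something is new, unique, unknown or untested is made for them only; others in the source may bear on it.

Compound 1 `OCc1cccc(-c2csc(=S)[nH]2)c1` has been tested in an assay on isolated protein for inhibition of Indoleamine 2,3-dioxygenase 1 (Homo sapiens), read by colorimetric assay, with stated times of 10 min and 30 min, tested at 100 uM (a higher number here means more inhibition at the concentration tested (going by the name of the read-out), a lower number less inhibition), and gives 16%, the lower of the two numbers in hand. Compound 2 `Fc1ccc(-c2csc(S)n2)cc1` gives 72% in this assay, a gap that lies beyond the scatter. Compound 3 `S=c1[nH]c(-c2cccc(Br)c2)cs1` is not yet measured; it differs from compound 1 in one place: bromo in place of hydroxymethyl on an aromatic carbon. Among the compounds with values here, no step between two measured compounds covers this change, so its size is open. A rise beyond the scatter is nonetheless expected, because compound 2 sits far higher at 72%. For compound 3 an inhibition of 50% is estimated, within 25% to 75%. The expected step is a number 34 percentage points higher from compound 1 to compound 3 (beyond the scatter).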

Compound 3, a percentage reported as inhibition, at one concentration (the size of the read-out at that concentration, not a potency): 81%
The estimate for compound 3 lay 31 percentage points below the measured number; the whole stated range lies below it.
By their numbers in this assay, from the lowest: compound 1; then compounds 2 and 3 (each within the scatter of the next).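

In this assay, bromo in place of hydroxymethyl on this aromatic carbon gives a number 65 percentage points higher from compound 1 to compound 3 (beyond the scatter) and so shows that the read-out depends strongly on the group at this position. Hydroxymethyl carries a hydrogen-bond donor and acceptor and bromo carries neither, but this single step cannot separate that difference from the change of group itself. Nothing in hand accounts for the size of the step.

As far as these compounds go, it remains open whether chloro or methyl on the same carbon would match bromo. An amine or a carboxylic acid there is equally untested in the compounds shown.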